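The compounds below may be only part of what the source reports. "The series", "measured", "known", "first", "only" and "open" are said of these compounds alone.

Compound 3 `CCCCCCNc1nccnc1C(=O)NCc1ccccc1` is tested in an ADME assay on MDCK cells (Canis lupus familiaris) for cytotoxicity, read by microscopy, with a stated time of 6 days (on this read-out higher numbers stand for lower toxicity in this test and lower numbers for higher toxicity in this test), where compound 3 gives 100000 nM. Compound 2 `CCCCNc1nccnc1C(=O)NCc1ccccc1` differs from compound 3 by hydrogen in place of ethyl on a saturated chain carbon, four bonds along the chain from a nitrogen on an aromatic ring. In this assay compound 2 reports a limit of the test rather than a number, > 100000 nM. One of the three values thus sits at the limit of > 100000 nM in this assay, at which 1 of the 3 values shown sits, and the step of a number no lower from compound 3 to compound 2 (the limit leaves the size open) is no lower, its size left open. Compound 1 `CCCCCCNc1cncc(C(=O)NCc2ccccc2)n1` has the same atoms joined differently; how its core differs from that of compound 3 is not broken down here. In this assay compound 1 gives 20000 nM, the lowest of the two numbers, with compound 3 higher by a step beyond the usual scatter. Compound 4 `CCCCNc1cncc(C(=O)NCc2ccccc2)n1` carries the same change as compound 2, namely (hydrogen in place of ethyl on a saturated chain carbon, four bonds along the chain from a nitrogen on an aromatic ring). Because the step of a number no lower from compound 3 to compound 2 (the limit leaves the size open) went no lower, compound 4 is expected to show a step of a 2.0-fold higher number from compound 1 to compound 4 (0.30 log units; within the scatter) in the same direction. Compound 4 is therefore estimated at 40000 nM.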

Compound 4, minimum cytotoxic concentration: 100000 nM
The estimate for compound 4 lay 2.5-fold (0.40 log units) below the measured number; the range from low to high includes it.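

Putting hydrogen in place of ethyl gives a 5.0-fold higher number from compound 1 to compound 4 (0.70 log units; beyond the scatter) in this assay on the core of compound 1, a rise larger than the usual scatter. Compound 2 gives > 100000 nM which is a limit of the test and not a number. The change therefore lowers the number on neither core, but the size of the step on the other core cannot be read, so this does not show that the change carries over with the same size: the same change on two cores in this assay, a number no lower (the limit leaves the size open) from compound 3 to compound 2 and a 5.0-fold higher number (0.70 log units; beyond the scatter) from compound 1 to compound 4; the limit leaves it open whether they differ

The compounds shown leave open whether a shorter chain, a longer chain, or a chain ending in an amine or a carboxylic acid would behave in the same way on either core. Two cores also cannot say whether the change would hold on a third.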